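This account rests on a few compounds, and the source may have more. Where it says the series, first, only, none or still open, it means among the compounds named here.

Measured compounds:
compound 1, `CCCc1nc(-c2ccccc2)c(CNCCN2CCN(c3ccccc3OC)CC2)o1`: 39.7%
compound 2, `CCCc1nc(-c2ccccc2)c(CNCCCN2CCN(c3cccc(F)c3)CC2)o1`: 68.9%
compound 3, `Cc1nc(-c2ccccc2)c(CNCCCN2CCN(c3ccc(Cl)cc3)CC2)o1`: 38.1%

Of the compounds shown here, three built on the same core have been tested in an assay on HEK293 cells for inhibition of Voltage-dependent T-type calcium channel subunit alpha-1G (Homo sapiens), read by fluorescence, tested at 10 uM; a lower number here means less inhibition, a higher number more inhibition at the concentration tested (going by the name of the read-out). Compound 2 stands at the top of this small set: its value of 68.9% is the highest of the three. The nearest number belongs to compound 1, which lies well below it, and compound 3 lies lower still, so both gaps are larger than the usual scatter of repeated measurements.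

The compound not yet measured is compound 4, `CCCc1nc(-c2ccccc2)c(CNCCCN2CCN(c3ccccc3OC)CC2)o1`. It differs from compound 2 in one place: 2-methoxyphenyl in place of 3-fluorophenyl on an amine nitrogen in a ring. Within the data shown here, no step between two measured compounds that differ in a single place has been recorded here, so the size of this change in this assay is not known from a direct comparison.

The expectation is that compound 4 will lose ground relative to compound 2, with a step of a number 21.9 percentage points lower from compound 2 to compound 4 (beyond the scatter), because compound 1 gives only 39.7% while compound 2 reaches 68.9%. The estimated inhibition for compound 4 is therefore 47%, with a likely range from 28% to 66%.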

Compound 4, a percentage reported as inhibition, at one concentration (the size of the read-out at that concentration, not a potency): 41%
Beside the measured number, compound 4's estimate is 6 percentage points above it; the range from low to high includes it.
By their numbers in this assay, from the lowest: compounds 3, 1 and 4 (each within the scatter of the next); then compound 2.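

Among these compounds, this is the first comparison in the set where only one place changes: in this assay, 2-methoxyphenyl in place of 3-fluorophenyl on the ring amine nitrogen gives a number 27.9 percentage points lower from compound 2 to compound 4 (beyond the scatter), so the group at this position clearly affects the read-out. The step changes both the substituent on the phenyl ring and the number in the group's name, and the entering group also adds a hydrogen-bond acceptor, so this single pair cannot show which difference matters. Nothing measured here explains the drop.

As far as these compounds go, it remains open whether the kind of substituent or its place on the phenyl ring carries the step: 3-methoxyphenyl and 2-fluorophenyl would separate the two, while plain phenyl would give a reference without any substituent. From the compounds shown here alone, it is also open whether the step would keep its size with a longer chain elsewhere on the shared core.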